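Removing the acyl group from a cytotoxic amide core

The compounds below may be only part of what the source reports. "The series", "measured", "known", "first", "only" and "open" are said of these compounds alone.

Compound 1 `O=C(Nc1cc(C(F)(F)F)cc(C(F)(F)F)c1)C1CCc2ccccc2N1C(=O)c1ccccc1Cl`: in a functional assay on ACHN cells (Homo sapiens) for cytotoxicity, read by sulforhodamine B assay, with a stated time of 72 h (on this read-out higher numbers stand for weaker inhibition of growth and lower numbers for stronger inhibition of growth), compound 1 gives 4700 nM.
Compound 2 `CCCC(=O)N1c2ccccc2CCC1C(=O)Nc1cc(C(F)(F)F)cc(C(F)(F)F)c1`: in this assay compound 2 gives 13900 nM.
Compound 3 `CCCCCCCCC(=O)N1c2ccccc2CCC1C(=O)Nc1cc(C(F)(F)F)cc(C(F)(F)F)c1`: in this assay compound 3 gives 4520 nM.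

Compound 3 holds the lowest of the three numbers, but its gap to compound 1 is within the scatter, so those two cannot be ordered; only compound 2 stands apart, as a 3.1-fold lower number from compound 2 to compound 3 (0.49 log units; beyond the scatter) shows. The unmeasured compound 4 `O=C(Nc1cc(C(F)(F)F)cc(C(F)(F)F)c1)C1CCc2ccccc2N1` differs from compound 3 by hydrogen in place of octylcarbonyl on a nitrogen on an aromatic ring in a ring: the whole octylcarbonyl group leaves and a bare hydrogen remains on that nitrogen. Going by the values given here, none of the measured steps removes the acyl group; they only swap what sits on its carbonyl carbon. Within these compounds, a 3.0-fold higher number from compound 1 to compound 2 (0.47 log units; beyond the scatter) and a 3.1-fold lower number from compound 2 to compound 3 (0.49 log units; beyond the scatter) show that a shorter chain there goes with modestly weaker growth inhibition, while a 1.0-fold lower number from compound 1 to compound 3 (0.02 log units; within the scatter) shows octyl and 2-chlorophenyl giving about the same number. Taking the acyl group away entirely goes further than any measured change, so a modest weakening beyond the scatter is expected, with wide uncertainty. Compound 4 is therefore estimated at 15000 nM, between 4000 nM and 60000 nM, which means an expected step of a 3.3-fold higher number from compound 3 to compound 4 (0.52 log units; beyond the scatter).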

Compound 4, concentration for 50% growth inhibition: 8190 nM
For compound 4 the middle estimate is 1.8-fold (0.26 log units) above the measured one, and the stated range covers the measured number.
By their numbers in this assay, from the lowest: compounds 3, 1, 4 and 2 (each within the scatter of the next, the first and the last beyond it).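

Taking the whole acyl group off this nitrogen leaves a number that cannot be separated from any of the three acylated compounds in this assay: the replacement of octylcarbonyl by hydrogen (a 1.8-fold higher number from compound 3 to compound 4 (0.26 log units; within the scatter)), of (2-chlorophenyl)carbonyl by hydrogen (a 1.7-fold higher number from compound 1 to compound 4 (0.24 log units; within the scatter)) and of propylcarbonyl by hydrogen (a 1.7-fold lower number from compound 2 to compound 4 (0.23 log units; within the scatter)) all stay within the scatter. Among these four compounds, then, growth inhibition in this range does not depend on an acyl group at this position, even though the choice of chain on the carbonyl carbon does separate two of the acylated compounds (a 3.1-fold lower number from compound 2 to compound 3 (0.49 log units; beyond the scatter)). No measurement at hand explains why the bare nitrogen holds up this way.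

Still open, on these data alone, is whether a group attached to this nitrogen without a carbonyl, such as a plain octyl chain, or an acyl chain ending in an amine or a carboxylic acid, would move the number beyond the scatter. Also open, as far as these compounds go, is whether this tolerance at the nitrogen would hold in other cell lines.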